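Methylsulfonyl on the amine nitrogen: an expectation for compound 4

The source may hold more compounds than are shown below. What is called first, only, known or untested is meant among the compounds shown, and "the series" means these compounds.

Measured so far:
compound 1, `COc1cccc(S(=O)(=O)c2ccc3c(c2)CCC[C@H]3CN)c1`: 0.398 nM
compound 2, `NC[C@@H]1CCCc2cc(S(=O)(=O)c3cccc(F)c3)ccc21`: 0.0794 nM
compound 3, `O=S(=O)(O)CCCNC[C@@H]1CCCc2cc(S(=O)(=O)c3cccc(F)c3)ccc21`: 1.26 nM

All three share a core and are measured in an assay on isolated protein for displacement of a labelled ligand from 5-hydroxytryptamine receptor 6 (Homo sapiens); a lower number here means a stronger inhibitor, a higher number a weaker inhibitor. Compound 3 shows the highest number of the three; compound 1 stands nearest to it, compound 2 furthest. The step of a 5.0-fold lower number from compound 1 to compound 2 (0.70 log units; beyond the scatter) follows a fluoro in place of methoxy on an aromatic carbon. The step of a 16-fold higher number from compound 2 to compound 3 (1.20 log units; beyond the scatter) follows a 3-sulfopropyl in place of hydrogen on an amine nitrogen.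

Compound 4, `CS(=O)(=O)NC[C@@H]1CCCc2cc(S(=O)(=O)c3cccc(F)c3)ccc21`, differs from compound 3 in one place: methylsulfonyl in place of 3-sulfopropyl on an amine nitrogen. Within the data shown here, only the step from compound 2 to compound 3 bears on it, as it also alters the amine nitrogen; it was large and towards a higher number. Among the measured compounds shown here, no measured pair shows a methylsulfonyl on that nitrogen, so the direction is uncertain. Compound 4 is expected to stay near compound 3, with a step of a 2.4-fold higher number from compound 3 to compound 4 (0.38 log units; beyond the scatter) not clearly beyond the scatter. The estimate for compound 4 is 3 nM, within 0.5 nM to 30 nM.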

Compound 4, inhibition constant: 0.2 nM
Estimate against measurement, compound 4: 15-fold (1.18 log units) above; measured number below the stated range.
By their numbers in this assay, from the lowest: compound 2; then compounds 4 and 1 (each within the scatter of the next); then compound 3.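

In this assay a substituent on the amine nitrogen does not carry a single penalty: a 6.3-fold lower number from compound 3 to compound 4 (0.80 log units; beyond the scatter) follows the exchange of 3-sulfopropyl for methylsulfonyl, so the rise seen with 3-sulfopropyl depends on the group placed there. Methylsulfonyl does not fully match the free amine, since a 2.5-fold higher number from compound 2 to compound 4 (0.40 log units; beyond the scatter) remains beyond the scatter, although it is smaller than a 16-fold higher number from compound 2 to compound 3 (1.20 log units; beyond the scatter) on the same nitrogen. No measurement on these compounds explains why the two groups differ.

The compounds shown leave open where a plain methyl, an acetyl or a propyl chain ending in a carboxylic acid on that nitrogen would stand relative to compound 2 and compound 4. They also leave open whether methylsulfonyl gives a similar step when the aromatic fluoro is replaced by the methoxy of compound 1.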